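The compounds below may be only part of what the source reports. "The series", "measured", "known", "first", "only" and "open" are said of these compounds alone.

Going by the values given here, compound 2 `Cc1ccc(C(=O)Nc2c(C(O)(C(F)(F)F)C(F)(F)F)ccc3ccccc23)cc1` gives 76 nM in an assay on LtK cells with ATP-sensitive inward rectifier potassium channel 11 (Homo sapiens) as the target (a lower number here means that less compound is needed, a higher number that more compound is needed for the effect), the lowest of the two numbers measured, yet its only neighbour, compound 1 `O=C(Nc1c(C(O)(C(F)(F)F)C(F)(F)F)ccc2ccccc12)c1cccc(C(F)(F)F)c1`, gives 84 nM in this assay, and the gap between them lies within the scatter, so no order can be drawn between the two. Among the compounds with values here, the single measured step, a 1.1-fold lower number from compound 1 to compound 2 (0.04 log units; within the scatter), exchanged the group on the carbonyl carbon and left the read-out essentially unchanged. Compound 3 `O=C(Nc1c(C(O)(C(F)(F)F)C(F)(F)F)ccc2ccccc12)c1cccc(Cl)c1Cl` differs from compound 2 by 2,3-dichlorophenyl in place of 4-methylphenyl on a carbonyl carbon. Because that earlier step a 1.1-fold lower number from compound 1 to compound 2 (0.04 log units; within the scatter) altered the same position without moving the number beyond the scatter, the expected step of a 1.1-fold higher number from compound 2 to compound 3 (0.02 log units; within the scatter) is likewise small, with no direction that can be trusted. On that basis compound 3 is estimated at 80 nM in this assay, with a range from 30 nM to 220 nM.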

Compound 3, half-maximal effective concentration: > 10000 nM
Compound 3 was reported as a limit (the forecaster's own chance of this, stated with the estimate: 0%); at least 120-fold (2.09 log units) between middle value and limit.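

The group on this carbonyl carbon is less freely exchangeable than the first pair suggested. In this assay, 3-(trifluoromethyl)phenyl and 4-methylphenyl could not be told apart, whereas 2,3-dichlorophenyl brings an at least 130-fold higher number from compound 2 to compound 3 (2.11 log units; beyond the scatter) and likewise an at least 110-fold higher number from compound 1 to compound 3 (2.07 log units; beyond the scatter), so exchanging one substituted phenyl for another is not always neutral here. The value of compound 3 is a limit and not a number, which leaves the full size of both steps unfixed: the limit of > 10000 nM in this assay, at which 1 of the 3 values shown sits.

As far as these compounds go, the two chlorines enter together, so it stays open whether a single chlorine would already give so large a step or whether both are needed. From the compounds shown here alone, how an unsubstituted phenyl, a methoxy group or an amine on this ring would read in this assay also remains open.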